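A few compounds are considered here, and "the series" means these few. Any claim that something is new, unique, unknown or untested is made for them only; others in the source may bear on it.

Measured in an assay for inhibition of Amine oxidase [flavin-containing] A (Homo sapiens); on this read-out lower numbers stand for stronger inhibition and higher numbers for weaker inhibition:
- compound 1, `O=C1O[C@@H](Cn2ccnn2)CN1c1ccc(-c2ccc(CO)nc2)c(F)c1`, gives 4800 nM
- compound 2, `O=C(c1ccc(-c2ccc(N3C[C@H](Cn4ccnn4)OC3=O)cc2F)cn1)C1CNC1`, gives 4500 nM

Compound 1 has the highest of the two numbers in this assay; compound 2 lies within the scatter of it, a 1.1-fold lower number from compound 1 to compound 2 (0.03 log units; within the scatter).

Compound 3, `CN1CCN(CCCC(=O)c2ccc(-c3ccc(N4C[C@H](Cn5ccnn5)OC4=O)cc3F)cn2)CC1`, is not yet measured. Against compound 1 it differs at one place, on an aromatic carbon of a six-membered aromatic ring with one nitrogen, next to the ring nitrogen, para to a large group: (3-(4-methylpiperazin-1-yl)propyl)carbonyl in place of hydroxymethyl on an aromatic carbon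

For the measured compounds named here, the only step that bears on this is the one from compound 1 to compound 2, where a carbonyl-bearing group also replaced hydroxymethyl at the same carbon and gave a 1.1-fold lower number from compound 1 to compound 2 (0.03 log units; within the scatter). The step in this assay is therefore expected to be none beyond the scatter, a 1.1-fold lower number from compound 1 to compound 3 (0.06 log units; within the scatter). For compound 3 the estimate in this assay is 4200 nM, within 1500 nM to 12000 nM.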

Compound 3, inhibition constant in the Amine oxidase [flavin-containing] A assay: 10500 nM
Compound 3: middle estimate off by 2.5-fold (0.40 log units), on the low side; the measured number falls inside the stated range.
By their numbers in the Amine oxidase [flavin-containing] A assay, from the lowest: compounds 2 and 1 (each within the scatter of the next); then compound 3.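

In the Amine oxidase [flavin-containing] A assay, this position no longer looks indifferent to the group on the carbonyl: a 2.2-fold higher number from compound 1 to compound 3 (0.34 log units; beyond the scatter), and a 2.3-fold higher number from compound 2 to compound 3 (0.37 log units; beyond the scatter). In a physicochemical assay for solubility, read by nephelometry (on this read-out higher numbers stand for higher solubility and lower numbers for lower solubility), compound 1 gives 100000 nM. In the physicochemical assay, compound 3 gives > 400000 nM, which is a limit of the assay and not a number: the limit of > 400000 nM in the physicochemical assay, at which 1 of the 2 values shown sits.

From the compounds shown here alone, whether the weaker inhibition follows the propyl chain or the 4-methylpiperazine ring remains open. A shorter chain carrying the same ring, or a dimethylamino group on the same propyl chain, would separate the two.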